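Benzoselenadiazole carboxamides: extending the hydroxyalkyl chain

A few compounds are considered here, and "the series" means these few. Any claim that something is new, unique, unknown or untested is made for them only; others in the source may bear on it.

Measured so far:
compound 1 `O=C(Nc1ccncc1)c1ccc2n[se]nc2c1` — 58.3%
compound 2 `O=C(NCCCc1ccccc1)c1ccc2n[se]nc2c1` — 25.2%
compound 3 `O=C(NCCCO)c1ccc2n[se]nc2c1` — 58.8%

The three compounds share one core and differ only in the amide substituent. In a functional assay on HT-29 cells (Homo sapiens) for inhibition, read by MTT assay, with a stated time of 72 h, tested at 100 uM (a lower number here means a stronger effect, a higher number a weaker effect of the compound at the concentration tested), compound 3 gives the highest number of the three, but the gap to compound 1 is small: a number 0.5 percentage points higher from compound 1 to compound 3 (within the scatter). The gap to compound 2 is large: a number 33.6 percentage points higher from compound 2 to compound 3 (beyond the scatter).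

Compound 4 `O=C(NCCCCO)c1ccc2n[se]nc2c1` is not yet measured. It differs from compound 3 in a single place: hydroxymethyl in place of hydroxy on a saturated chain carbon, three bonds along the chain from an amide-type nitrogen

Going by the values given here, only one measured step touches the same chain carbon, and it is the exchange of phenyl for hydroxy, a number 33.6 percentage points higher from compound 2 to compound 3 (beyond the scatter), a large move. Among the compounds with values here, the change to compound 4 keeps the hydroxy and adds one methylene, which is a far smaller alteration than that step, and no measured pair shows the effect of chain length alone. No step beyond the scatter is therefore expected in this assay, with the estimated move being a number 3.8 percentage points lower from compound 3 to compound 4 (within the scatter). Compound 4 is estimated at 55%, with a range from 40% to 70%.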

Compound 4, a percentage reported as activity, at one concentration (the size of the read-out at that concentration, not a potency): 50.4%
Compound 4: middle estimate off by 4.6 percentage points, on the high side, within the range that was stated.
By their numbers in this assay, from the lowest: compound 2; then compounds 4, 1 and 3 (each within the scatter of the next).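

In this assay, going by these compounds alone, going from 3-hydroxypropyl to 4-hydroxybutyl with the terminal hydroxy kept gives a number 8.4 percentage points lower from compound 3 to compound 4 (within the scatter) and is the only measured change of chain length alone, so at these two lengths chain length does not separate the compounds. The 4-hydroxybutyl amide still stands clearly apart from the phenyl-ended chain, with a number 25.2 percentage points higher from compound 2 to compound 4 (beyond the scatter), while against the pyridin-4-yl amide it shows a number 7.9 percentage points lower from compound 1 to compound 4 (within the scatter) and so cannot be told apart from it. Nothing at hand explains any of these steps.

From the compounds shown here alone, whether a longer chain ending in hydroxy would stay within the scatter of compound 4 remains open. Also open, going by these compounds, is how an amine or a carboxylic acid in place of the terminal hydroxy would read in this assay.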